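The source may hold more compounds than are shown below. What is called first, only, known or untested is meant among the compounds shown, and "the series" means these compounds.

Compound 1, with the structure `CC(=O)N[C@@H](CSC(=O)Nc1ccc(I)cc1)C(=O)O`, was tested in a functional assay on OVCAR-3 cells (Homo sapiens) for cytotoxicity, read by MTT assay, with a stated time of 6 days; on this read-out higher numbers stand for weaker inhibition and lower numbers for stronger inhibition. In this assay compound 1 gives only a limit, > 200000 nM, rather than a measured number. A second compound, compound 2 with the structure `COc1ccccc1CNC(=O)SC[C@H](NC(C)=O)C(=O)O`, was examined in the same way. In this assay compound 2 also gives only a limit, > 200000 nM. Compound 1 therefore stands at the limit of > 200000 nM in this assay, at which 2 of the 2 values shown sit, so no number places it above or below its companion, and nothing is known about how far either compound would have to change to reach a measurable value.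

The next compound, compound 3 with the structure `CC(=O)N[C@@H](CSC(=O)Nc1ccc(F)cc1)C(=O)O`, differs from compound 1 in a single spot: fluoro in place of iodo on an aromatic carbon. For the measured compounds named here, because both measured compounds sit at the same limit (the limit of > 200000 nM in this assay, at which 2 of the 2 values shown sit), the step from compound 1 to compound 3 is expected to be no step at all beyond the usual scatter, written here as a step that the limit leaves unreadable from compound 1 to compound 3. Compound 3 is therefore estimated to show 300000 nM in this assay, within a range from 100000 nM to 1000000 nM, and most likely to return a limit again rather than a number.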

Compound 3, half-maximal inhibitory concentration: > 200000 nM
Compound 3: a limit, no number (the forecaster's own chance of this, stated with the estimate: 85%); the middle value does not contradict the limit.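

Compound 3 also returns only a limit, so swapping iodo for fluoro between compound 1 and compound 3 cannot be read as a step of any size: the limit of > 200000 nM in this assay, at which 3 of the 3 values shown sit.

The compounds shown leave open how far apart they truly lie in this assay, and whether any change to the shared core would give a measured number there.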